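From piperidin-1-yl to 4-hydroxypiperidin-1-yl in compound 3

The source may hold more compounds than are shown below. What is called first, only, known or untested is meant among the compounds shown, and "the series" means these compounds.

In a functional assay on LOX IMVI cells (Homo sapiens) for inhibition, read by sulforhodamine B assay, with a stated time of 48 h (on this read-out lower numbers stand for stronger inhibition of growth and higher numbers for weaker inhibition of growth), compound 3 (`COc1cc2nc(-c3ccc(C(F)(F)F)cc3)cc(OCCCN3CCCCC3)c2cc1OC`) gives 162 nM. Among the compounds with values here, that is the middle of the three numbers so far, and it lies within the scatter of both others: compound 1 (`COc1cc2nc(-c3ccc(C(F)(F)F)cc3)cc(OCCCN3CCCC3)c2cc1OC`) gives 116 nM and compound 2 (`COc1cc2nc(-c3ccc(Cl)cc3)cc(OCCCN3CCC(O)CC3)c2cc1OC`) gives 227 nM. Compound 4 (`COc1cc2nc(-c3ccc(C(F)(F)F)cc3)cc(OCCCN3CCC(O)CC3)c2cc1OC`) departs from compound 3 in one place: hydroxy in place of hydrogen on a saturated ring carbon. This puts hydroxy in place of hydrogen on a saturated ring carbon. The only measured step among these compounds is a 1.4-fold higher number from compound 1 to compound 3 (0.15 log units; within the scatter), which swaps pyrrolidin-1-yl for piperidin-1-yl and stays within the scatter. Within the data shown here, no measured step isolates the hydroxy itself. Compound 4 also differs elsewhere from compound 2, which already carries 4-hydroxypiperidin-1-yl and gives 227 nM, so that value is only a loose guide. The expected step is a 1.2-fold higher number from compound 3 to compound 4 (0.07 log units; within the scatter), leaning toward a higher number but not beyond the scatter. For compound 4 the estimated value is 190 nM, with an expected range from 95 nM to 380 nM.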

Compound 4, concentration for 50% growth inhibition: 190 nM
The estimate for compound 4 equals the measured number at the digits printed; the range from low to high includes it.
By their numbers in this assay, from the lowest: compounds 1, 3, 4 and 2 (each within the scatter of the next).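

In this assay, within the data shown here, the step of a 1.2-fold higher number from compound 3 to compound 4 (0.07 log units; within the scatter) is the first measured reading of hydroxy in place of hydrogen on this saturated ring carbon, three ring bonds from the ring nitrogen, and the read-out does not separate the pair. Trifluoromethyl in place of chloro on an aromatic carbon, read as a 1.2-fold lower number from compound 2 to compound 4 (0.08 log units; within the scatter) in the presence of 4-hydroxypiperidin-1-yl, likewise leaves its pair unseparated, as does the swap of pyrrolidin-1-yl for 4-hydroxypiperidin-1-yl, read as a 1.6-fold higher number from compound 1 to compound 4 (0.21 log units; within the scatter) with trifluoromethyl in place. Nothing available gives a reason for these readings. On these data alone, whether an amine or a carboxylic acid on this ring carbon would give a step beyond the scatter remains open. So does whether hydroxy would read the same way on a longer chain.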